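The source may report more compounds than this note shows. Statements on the series, on what has been measured and on what is new or still open speak of the compounds shown alone.

Of the compounds shown here, two have been tested in an assay on isolated protein for inhibition of Aromatase (Homo sapiens), read by fluorescence, using NADPH, with a stated time of 30 min, tested at 50 uM (on this read-out higher numbers stand for more inhibition at the one concentration tested (going by the name of the read-out) and lower numbers for less inhibition), so far. Compound 1, `Nc1ccccc1C#Cc1cc(F)cc(F)c1`, gives 9.27% in this assay. Compound 2, `CO/N=C/c1c(-c2ccccc2)[nH]c2ccccc12`, gives 24.7% in this assay. On these two numbers compound 2 stands highest, and compound 1 sits lower by a gap that lies beyond the usual scatter of repeated measurements. For the measured compounds named here, the two compounds share no common core, so no single structural step links them, and nothing more can be read from their pair than the two values themselves.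

Compound 3, `O/N=C/c1c(-c2ccccc2)[nH]c2ccccc12`, is the next compound to be measured in this assay. It keeps the whole core of compound 2 and differs in one place only: hydrogen in place of methyl on an oxygen. This is a very small change at the edge of the molecule.

Going by the values given here, because the only anchor is compound 2 with its 24.7%, the step from compound 2 to compound 3 is expected to be small, a number 2.7 percentage points lower from compound 2 to compound 3 (within the scatter), with no clear direction and likely not beyond the scatter. Compound 3 is therefore estimated at 22% in this assay, within a range from 8% to 38%.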

Compound 3, a percentage reported as inhibition, at one concentration (the size of the read-out at that concentration, not a potency): 40.4%
Estimate against measurement, compound 3: 18.4 percentage points below, outside the stated range (above it).
By their numbers in this assay, from the lowest: compound 1; then compound 2; then compound 3.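

Within the shared core of compound 2 and compound 3, the switch from methoxy to hydroxy, on an oxygen whose other neighbour is a double-bonded nitrogen, appears in this assay as a number 15.7 percentage points higher from compound 2 to compound 3 (beyond the scatter) and so counts as a real difference. The first two compounds could not show this, since they have no core in common, whereas this pair ties a change in the read-out to one place in the molecule and shows that the methyl on this oxygen is not needed for the inhibition seen here. For the compounds shown here, nothing measured so far explains why removing a single methyl has this effect.

This is still one step on one core, read at a single concentration, so it shows neither a trend along a series of groups nor a potency. An ethyl group or a longer chain on the same oxygen would show whether the read-out keeps falling as the group grows, and an amine in place of the hydroxy would show whether the oxygen itself matters at this position.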